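Methoxy to hydroxy on the anilino-styryl arm of the series

The source may hold more compounds than are shown below. What is called first, only, known or untested is meant among the compounds shown, and "the series" means these compounds.

Compound 1 `COc1cc(N(C)C)ccc1/C=C1\C(=O)N(c2ccccc2)C(=S)N1C` is the reference point of this pair. In an assay on isolated protein for inhibition of NADPH oxidase 4 (Homo sapiens), read by chemiluminescence, in the presence of a further agent that is not named here (on this read-out higher numbers stand for weaker inhibition and lower numbers for stronger inhibition), compound 1 gives 2080 nM, the lowest of the two numbers in hand. Among the measured compounds shown here, the only measured neighbour, compound 2 `COc1cc(N(C)CCCO)ccc1/C=C1\C(=O)N(c2ccccc2)C(=S)N1C`, gives 2480 nM in this assay; the step of a 1.2-fold higher number from compound 1 to compound 2 (0.08 log units; within the scatter) shows that a 2-hydroxyethyl in place of hydrogen on a saturated chain carbon bound to a nitrogen on an aromatic ring leaves the read-out where it was.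

Compound 3 `CN1C(=S)N(c2ccccc2)C(=O)/C1=C\c1ccc(N(C)C)cc1O` is not yet measured. It differs from compound 1 by hydrogen in place of methyl on an oxygen on an aromatic ring; the difference, cut one bond further out, reads methoxy to hydroxy. For the measured compounds named here, no measured step touches this oxygen, so the step from compound 1 to compound 2 bears on it only in the general sense that the one change tried so far on the outer part of this ring stayed within the scatter. Nothing in the data points to a direction. From the compounds shown here alone, compound 3 is therefore expected to give about 2500 nM in this assay, between 900 nM and 7000 nM, an estimated step of a 1.2-fold higher number from compound 1 to compound 3 (0.08 log units; within the scatter) from compound 1, with the wide range reflecting that the change is untested here.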

Compound 3, half-maximal inhibitory concentration: 3430 nM
Compound 3: middle estimate off by 1.4-fold (0.14 log units), on the low side, and the stated range covers the measured number.
By their numbers in this assay, from the lowest: compounds 1, 2 and 3 (each within the scatter of the next).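

Putting hydrogen in place of methyl on an oxygen on an aromatic ring, methoxy to hydroxy, gives in this assay a 1.6-fold higher number from compound 1 to compound 3 (0.22 log units; within the scatter) and thus stays inside the usual spread of this read-out. Among the compounds shown here, this is the first measured change at this oxygen, and it shows that the methyl, one heavy atom with no hydrogen-bond donor or acceptor counted for it, can be removed without a step beyond the scatter. With a 1.2-fold higher number from compound 1 to compound 2 (0.08 log units; within the scatter) at the nitrogen on the aromatic ring, two single changes at two different places have now been read from compound 1, and neither goes beyond the scatter, while no evidence at hand bears on the reason for this result.

Open, from the compounds shown here alone, is whether this oxygen tolerates more than a methyl, for example an ethyl group, a longer chain or a chain ending in a carboxylic acid, or whether such groups would produce a step beyond the scatter. Also open, going by these compounds, is whether an amine in place of the hydroxy would give a read-out within the scatter of compound 3 as well.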